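The source may report more compounds than this note shows. Statements on the series, on what has been measured and on what is new or still open speak of the compounds shown alone.

Among the compounds with values here, in a functional assay on MDA-MB-231 cells (Homo sapiens) for antiproliferative activity, read by MTT assay, with a stated time of 24 h (on this read-out lower numbers stand for stronger inhibition and higher numbers for weaker inhibition), compound 3 `COc1ccc(-c2cc(/C=C/C(=O)c3ccc(C)c(C)c3)nc3cc(-c4ccccc4)nn23)cc1OC` gives 11500 nM, the low end of three numbers, though only the step of a 2.1-fold lower number from compound 1 to compound 3 (0.31 log units; beyond the scatter) lies beyond the scatter. Compound 2 `COc1ccc(-c2cc(/C=C/C(=O)c3ccc(C)cc3)nc3cc(-c4ccccc4)nn23)cc1OC` gives 19800 nM and compound 1 `COc1ccc(-c2cc(C(=O)/C=C/c3ccc(Cl)cc3)nc3cc(-c4ccccc4)nn23)cc1OC` gives 23700 nM; the step of a 1.7-fold lower number from compound 2 to compound 3 (0.24 log units; within the scatter) shows that adding one methyl brought no sure change. Compound 4 `COc1ccc(C(=O)/C=C/c2cc(-c3ccc(OC)c(OC)c3)n3nc(-c4ccccc4)cc3n2)cc1` differs from compound 3 by 4-methoxyphenyl in place of 3,4-dimethylphenyl on a carbonyl carbon. The measured steps that bear on this are a 1.2-fold lower number from compound 1 to compound 2 (0.08 log units; within the scatter) and a 1.7-fold lower number from compound 2 to compound 3 (0.24 log units; within the scatter), each small even when the whole arm was exchanged, so for the swap of one aromatic ring here a step no larger than the scatter is expected, a 1.4-fold higher number from compound 3 to compound 4 (0.14 log units; within the scatter), if anything toward a slightly higher number. Compound 4 is therefore estimated at 16000 nM, with a range from 7000 nM to 36000 nM.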

Compound 4, half-maximal inhibitory concentration: 13900 nM
Compound 4: middle estimate off by 1.2-fold (0.06 log units), on the high side; low and high end bracket the measured number.
By their numbers in this assay, from the lowest: compounds 3, 4, 2 and 1 (each within the scatter of the next, the first and the last beyond it).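

In this assay, 4-methoxyphenyl in place of 3,4-dimethylphenyl on the carbonyl carbon gives a 1.2-fold higher number from compound 3 to compound 4 (0.08 log units; within the scatter) and so brings no sure change, even though the entering ring carries an oxygen. Methoxy in place of methyl gives a 1.4-fold lower number from compound 2 to compound 4 (0.15 log units; within the scatter) and also stays inside the scatter, as does the exchange of the whole arm, which gives a 1.7-fold lower number from compound 1 to compound 4 (0.23 log units; within the scatter) with compound 4 as its end point. No measurement here offers an explanation for these results. Still open, on these data alone, is whether an amine or a carboxylic acid on this ring would move the number beyond the scatter.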